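The source may report more compounds than this note shows. Statements on the series, on what has been measured and on what is new or still open speak of the compounds shown alone.

Two compounds of the series have so far been run in a functional assay on HT-29 cells (Homo sapiens) for antiproliferative activity, read by sulforhodamine B assay, with a stated time of 72 h; a higher number here means a weaker inhibitor, a lower number a stronger inhibitor. Compound 1 `CCCCCCCCc1ccc(CCC(CO)(CO)NC(=O)CCC)c2ccccc12` gives 26400 nM. Compound 2 `CCCCCCCCc1ccc(CCC(CO)(CO)NC(=O)CCCCC)c2ccccc12` gives 20300 nM. The step of a 1.3-fold lower number from compound 1 to compound 2 (0.11 log units; within the scatter), so the two measured compounds sit within the scatter of each other and compound 2 is not separated from compound 1 by anything beyond it. The next compound, compound 3 `CCCCCCCCc1ccc(CCC(CO)(CO)NC(=O)C(C)CC)c2ccccc12`, has not been measured. Relative to compound 2 it carries sec-butyl in place of pentyl on a carbonyl carbon. For the measured compounds named here, the only measured step touching the acyl chain is a 1.3-fold lower number from compound 1 to compound 2 (0.11 log units; within the scatter), a change of chain length that stayed within the scatter; nothing measured addresses a branched chain. With that background, the step for compound 3 in this assay is expected to be a 1.2-fold higher number from compound 2 to compound 3 (0.09 log units; within the scatter), none beyond the scatter. Compound 3 is estimated at 25000 nM, with a range of 10000 nM to 60000 nM.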

Compound 3, half-maximal inhibitory concentration: 25600 nM
Beside the measured number, compound 3's estimate is 1.0-fold (0.01 log units) below it, within the range that was stated.
By their numbers in this assay, from the lowest: compounds 2, 3 and 1 (each within the scatter of the next).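

Working notes on the acyl position: in this assay, sec-butyl in place of pentyl on a carbonyl carbon gives a 1.3-fold higher number from compound 2 to compound 3 (0.10 log units; within the scatter) and thus puts a branched chain within the scatter of the straight pentyl chain. Methyl in place of hydrogen on a saturated chain carbon bound to a carbonyl carbon and a saturated chain carbon gives a 1.0-fold lower number from compound 1 to compound 3 (0.01 log units; within the scatter) and thus shows that this branch point also leaves compound 3 within the scatter of compound 1, so neither a change of length nor a branch has yet produced a step beyond the scatter. No evidence at hand bears on these results.

From the compounds shown here alone, whether a longer chain, a phenyl ring or an amine on the acyl chain would give a step beyond the scatter stays open. Also open, going by these compounds, is whether a carboxylic acid there would do so.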